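Taking the Methyl Group off Compound 3

The compounds below may be only part of what the source reports. "The series", "measured", "known", "first", "only" and "open" are said of these compounds alone.

For the measured compounds named here, in a functional assay on HepG2 cells (Homo sapiens) for antiproliferative activity, read by MTT assay, with a stated time of 48 h (on this read-out higher numbers stand for weaker inhibition and lower numbers for stronger inhibition), compound 3 `COc1ccc(/C=C/c2cc(OC)cc(OC)c2/C=C/C(=O)c2ccccc2C)cc1` gives 5.3 ug/mL, the lowest of the three numbers so far. Compound 1 `COc1ccc(/C=C/c2cc(OC)cc(OC)c2/C=C/C(=O)c2cccc(OC)c2)cc1` gives 11.6 ug/mL, and compound 2 `COc1ccc(/C=C/c2cc(OC)cc(OC)c2/C=C/C(=O)c2ccc(Br)cc2)cc1` gives 12.9 ug/mL. Compound 4 `COc1ccc(/C=C/c2cc(OC)cc(OC)c2/C=C/C(=O)c2ccccc2)cc1` differs from compound 3 by hydrogen in place of methyl on an aromatic carbon, turning 2-methylphenyl into phenyl. The closest evidence is modest: a 2.2-fold lower number from compound 1 to compound 3 (0.34 log units; beyond the scatter) and a 2.4-fold lower number from compound 2 to compound 3 (0.39 log units; beyond the scatter). By contrast, a 1.1-fold higher number from compound 1 to compound 2 (0.05 log units; within the scatter) stays within the scatter. Going by the values given here, no measured compound carries plain phenyl, so losing the methyl may simply return the number partway towards those of the other two compounds. A modest rise is therefore expected, estimated as a 1.7-fold higher number from compound 3 to compound 4 (0.23 log units; within the scatter). The expected value for compound 4 is 9 ug/mL, with an estimated range of 4.5 ug/mL to 18 ug/mL.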

Compound 4, half-maximal inhibitory concentration: 6.8 ug/mL
The estimate for compound 4 lay 1.3-fold (0.12 log units) above the measured number; measured number inside the range.
By their numbers in this assay, from the lowest: compounds 3, 4, 1 and 2 (each within the scatter of the next, the first and the last beyond it).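

In this assay the methyl group can go without a change beyond the scatter (a 1.3-fold higher number from compound 3 to compound 4 (0.11 log units; within the scatter)), so compound 3 does not depend measurably on it. Plain phenyl also stays within the scatter of the bromo and methoxy rings (a 1.9-fold lower number from compound 2 to compound 4 (0.28 log units; within the scatter); a 1.7-fold lower number from compound 1 to compound 4 (0.23 log units; within the scatter)), which makes compound 4 a neutral reference that cannot be separated from any of the other three compounds. No available measurement explains these small steps. Still open, on these data alone, is whether an amine or a carboxylic acid on the carbon that carries methyl in compound 3 would move the number beyond the scatter.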